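A few compounds are considered here, and "the series" means these few. Any claim that something is new, unique, unknown or untested is made for them only; others in the source may bear on it.

Measured compounds:
Compound 1 `CCCn1c(NC(=O)c2cncn2C)nc2cc(C(N)=O)cc(OC)c21`: in an assay for activation of interferon regulatory factor 3 (Homo sapiens), read by a luciferase reporter, with a stated time of 20 h (on this read-out higher numbers stand for an effect only at larger amounts of compound and lower numbers for an effect already at smaller amounts), compound 1 gives > 100000 nM, which is a limit of the assay and not a number.
Compound 2 `COc1cc(C(N)=O)cc2nc(NC(=O)c3cncn3C)n(CCCNC(=O)OCc3ccccc3)c12`: in this assay compound 2 gives > 100000 nM, again a limit of the assay rather than a number.

Among the compounds with values here, compound 2 therefore stands at the limit, as does the one further value shown, (the limit of > 100000 nM in this assay, at which 2 of the 2 values shown sit). The step that the two limits leave unreadable from compound 1 to compound 2 cannot be read from two limits. Compound 3 `COc1cc(C(N)=O)cc2nc(NC(=O)C3CCN(C)CC3)n(CCCNC(=O)OCc3ccccc3)c12` differs from compound 2 by 1-methylpiperidin-4-yl in place of 1-methyl-1H-imidazol-5-yl on a carbonyl carbon. Within the data shown here, no measured step bears on this change, so there is no basis for expecting a step in this assay in either direction, and compound 3 is expected most likely to remain at the limit. The estimate for compound 3 is 100000 nM (range 20000 nM to 300000 nM), an expected step of a number no higher from compound 2 to compound 3 (the limit leaves the size open).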

Compound 3, half-maximal effective concentration: > 100000 nM
Compound 3 ended at the assay's limit; the forecaster's own chance of this, stated with the estimate: 80%; the middle value sits exactly at the limit.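

In this assay compound 3 gives > 100000 nM as a limit and not a number, so no step can be read from compound 2 to compound 3. The compounds shown leave open whether any such change can bring a measurable value in this assay at all.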